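Swapping a chloropyridinyl arm for phenyl in a CXCR4 series

A few compounds are considered here, and "the series" means these few. Any claim that something is new, unique, unknown or untested is made for them only; others in the source may bear on it.

Compound 1 `Clc1cccc(NCc2ccc(CNc3ncccn3)cc2)n1` gives the highest of the three measured numbers in a functional assay on MDA-MB-231 cells for antagonist activity at C-X-C chemokine receptor type 4 (Homo sapiens), tested at 10 nM (a lower number here means a weaker effect, a higher number a stronger effect of the compound at the concentration tested), namely 100%. Compound 2 `Fc1ccc(NCc2ccc(CNc3ccc(F)cn3)cc2)nc1` gives 45% in this assay, a number that lies below compound 1 beyond the scatter, and compound 3 `Fc1ccccc1NCc1ccc(CNc2ccccc2F)cc1` gives 32%, the furthest below compound 1. Compound 4 `c1ccc(NCc2ccc(CNc3ncccn3)cc2)cc1` has not yet been measured in this assay. It differs from compound 1 in one place: phenyl in place of 6-chloropyridin-2-yl on an amine nitrogen. Going by the values given here, no step between two measured compounds isolates this change, so the expectation rests on the spread of the three numbers alone. Since the compounds lacking the chloropyridinyl arm, compound 2 and compound 3, both sit well below compound 1, the step from compound 1 to compound 4 in this assay is expected to be downward, a number 45 percentage points lower from compound 1 to compound 4 (beyond the scatter), and beyond the scatter. Compound 4 is therefore estimated at 55%, with a range from 25% to 85%.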

Compound 4, a percentage reported as inhibition, at one concentration (the size of the read-out at that concentration, not a potency): 55%
For compound 4 middle estimate and measured number coincide at the digits printed; the measured number falls inside the stated range.
By their numbers in this assay, from the lowest: compound 3; then compounds 2 and 4 (each within the scatter of the next); then compound 1.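

Going by these compounds alone, with the rest of compound 1 kept, phenyl in place of 6-chloropyridin-2-yl on an amine nitrogen gives in this assay a number 45 percentage points lower from compound 1 to compound 4 (beyond the scatter) and is the first change here that can be read at one place alone. The step is large, so the group on this amine nitrogen clearly matters to the read-out. Nothing available explains why this change has so large an effect. The compounds shown leave open whether the chlorine or the ring nitrogen accounts for the step, which a pyridin-2-yl arm or a chlorophenyl arm could separate.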